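This account rests on a few compounds, and the source may have more. Where it says the series, first, only, none or still open, it means among the compounds named here.

Measured compounds:
compound 1 `C#CCNC1CCc2c(SCCc3cccc(Br)c3)cccc21` – 620 nM
compound 2 `C#CCNC1CCc2c(SCCc3cccc(Cl)c3)cccc21` – "not determined" (no result reported)

In an ADME assay on isolated protein for inhibition of Amine oxidase [flavin-containing] B (Homo sapiens) (a lower number here means a stronger inhibitor, a higher number a weaker inhibitor), compound 1 gives 620 nM. Compound 2 has no number in this assay, so where it stands cannot be said from these data; only compound 1 gives a reference point. Compound 3 `C#CCNC1CCc2c(SCCc3cccc(OC)c3)cccc21` differs from compound 2 by methoxy in place of chloro on an aromatic carbon. For the measured compounds named here, no measured step covers this change. A step of modest size in this assay is expected, more likely toward a weaker inhibitor, though a step within the scatter cannot be ruled out. Compound 3 is estimated at 1500 nM with a range from 300 nM to 6000 nM.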

Compound 3, half-maximal inhibitory concentration: 3820 nM
Beside the measured number, compound 3's estimate is 2.5-fold (0.41 log units) below it; low and high end bracket the measured number.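

In this assay, the aromatic carbon carrying the substituent now has a readable step: methoxy in place of bromo gives a 6.2-fold higher number from compound 1 to compound 3 (0.79 log units; beyond the scatter), so compound 3 is the weaker inhibitor of this pair and this position is sensitive to the change. The step between compound 2 and compound 3 cannot be read, since compound 2 has no number. No measurement at hand accounts for the step.

Where chloro stands relative to bromo and methoxy remains open. As far as these compounds go, how an amine or a carboxylic acid would compare at this position is also open.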